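The compounds below may be only part of what the source reports. "The series", "measured", "known", "first", "only" and "open" are said of these compounds alone.

Of the compounds shown here, three have been measured in an ADME assay on microsomes from liver (Rattus norvegicus) for metabolic stability, read by HPLC, with a stated time of 10 min, tested at 3 uM; a higher number here means that more of the compound is left, a lower number that less of the compound is left. Compound 1 `CC[C@H](C1CC1)n1cc(Cl)nc(Nc2cc(C)c(OC)nc2C)c1=O` gives 5%, compound 2 `COc1nc(C)c(Nc2nc(Cl)cn([C@H](C)C3CC3)c2=O)cc1C` gives 55%, and compound 3 `CC[C@H](C1CC1)n1cc(C#N)nc(Nc2cc(C)c(OC)nc2C)c1=O` gives 38%. Compound 3 therefore holds the second highest number of the three, with both gaps to the other compounds beyond the usual scatter.

Compound 4 `COc1nc(C)c(Nc2nc(C#N)cn([C@H](C)C3CC3)c2=O)cc1C` has not yet been measured. It keeps the cyano group of compound 3 and differs from it in one place: hydrogen in place of methyl on a saturated chain carbon, two bonds along the chain from an aromatic nitrogen and a saturated ring carbon. Hydrogen replaces methyl on a saturated chain carbon, turning 1-cyclopropylpropyl into 1-cyclopropylethyl.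

The same exchange has been measured once, on the chloro compounds, in the large step of a number 50 percentage points higher from compound 1 to compound 2 (beyond the scatter). The other measured exchange, cyano in place of chloro, gave the large step of a number 33 percentage points higher from compound 1 to compound 3 (beyond the scatter). Together, these two steps point to a higher number for compound 4. However, compound 3 starts from 38%, so it has less room on this percentage scale than compound 1 had, and the full size of the first step may not be repeated.

The estimated change is a number 40 percentage points higher from compound 3 to compound 4 (beyond the scatter). Compound 4 is expected to give 78%, with an estimated range from 60% to 92%.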

Compound 4, percent of the compound remaining: 72%
Estimate against measurement, compound 4: 6 percentage points above, within the range that was stated.
By their numbers in this assay, from the lowest: compound 1; then compound 3; then compound 2; then compound 4.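

In this assay, hydrogen in place of methyl on the saturated chain carbon, turning 1-cyclopropylpropyl into 1-cyclopropylethyl, gives a number 34 percentage points higher from compound 3 to compound 4 (beyond the scatter), so the number also rises with this change on the cyano compounds, but the two steps differ in size: the same change on two cores in this assay, a number 50 percentage points higher (beyond the scatter) from compound 1 to compound 2 and a number 34 percentage points higher (beyond the scatter) from compound 3 to compound 4, 16 percentage points apart, beyond the scatter of two such steps Cyano in place of chloro on the aromatic carbon also raises the number when 1-cyclopropylethyl is present, giving a number 17 percentage points higher from compound 2 to compound 4 (beyond the scatter), and this step is likewise smaller than its counterpart on the 1-cyclopropylpropyl compounds: the same change on two cores in this assay, a number 33 percentage points higher (beyond the scatter) from compound 1 to compound 3 and a number 17 percentage points higher (beyond the scatter) from compound 2 to compound 4, 16 percentage points apart, beyond the scatter of two such steps Both changes thus point the same way in all four compounds, yet each gives less when the other is already in place, and these numbers cannot tell whether that reflects the upper end of the percentage scale or a real dependence of one change on the other.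

The compounds shown leave open whether the number would change further with cyclopropylmethyl on the aromatic nitrogen, or with a carboxamide or trifluoromethyl on the aromatic carbon in place of cyano. They also do not show which part of the molecule is affected when the compound is lost, as the read-out gives only the amount remaining.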